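The source may hold more compounds than are shown below. What is called first, only, known or untested is meant among the compounds shown, and "the series" means these compounds.

Compound 1, `CC(C)c1ccc(NC(=O)N[C@@H](C)c2ccccc2)cc1`, gives 86% in an ADME assay on the whole organism with Oryza sativa as the target, tested at 10 uM; a lower number here means a stronger effect, a higher number a weaker effect of the compound at the concentration tested. Compound 2, `C[C@@H](NC(=O)Nc1ccc(C(C)(C)C)cc1)c1ccccc1`, gives 53%. Compound 3, `C[C@H](NC(=O)Nc1ccc(C(C)(C)C)cc1)c1ccccc1`, gives 64%.

Compound 2 stands lowest of the three numbers: compound 3 sits a number 11 percentage points higher from compound 2 to compound 3 (beyond the scatter), a shift that rests on (the fact that compounds 2 and 3 differ only in the configuration as drawn), and compound 1 lies furthest away, while compound 1 to compound 3 shows a number 22 percentage points lower from compound 1 to compound 3 (beyond the scatter). Compound 4, `CCOC(=O)c1ccc(NC(=O)N[C@H](C)c2ccccc2)cc1`, is not yet measured; it carries ethoxycarbonyl in place of tert-butyl on an aromatic carbon. Among the measured compounds shown here, neither measured step touches the group on the aromatic ring, so no step bears directly on this change, and an expectation of no shift beyond the scatter, with a wide range, is all the measured compounds support. The step from compound 2 to compound 4 is therefore expected to be a number 7 percentage points higher from compound 2 to compound 4 (within the scatter). Compound 4 is estimated at 60%, between 35% and 88%.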

Compound 4, a percentage reported as activity, at one concentration (the size of the read-out at that concentration, not a potency): 92%
The estimate for compound 4 lay 32 percentage points below the measured number; measured number above the stated range.
By their numbers in this assay, from the lowest: compound 2; then compound 3; then compounds 1 and 4 (each within the scatter of the next).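

In this assay the change of tert-butyl to ethoxycarbonyl gives a number 39 percentage points higher from compound 2 to compound 4 (beyond the scatter) and so shows that this aromatic carbon can carry a large step. It is also the first change shown that brings oxygen and hydrogen-bond acceptors to this place, where the earlier compounds hold only saturated carbon groups. Nothing known about these compounds bears on why this step occurs.

Going by these compounds, it remains open whether a carboxylic acid, an amine or a methyl ester at this place would read like compound 4 or like compound 2. Also open, on these data alone, is whether the difference in configuration seen between compounds 2 and 3 persists with ethoxycarbonyl.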